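A few compounds are considered here, and "the series" means these few. Any claim that something is new, unique, unknown or untested is made for them only; others in the source may bear on it.

Working notes on the series built on the core of compound 1 (`O=C(O)c1cnc(Oc2ccc3c(c2)B(O)OC3)cn1`). In an ADME assay (liver, Mus musculus) for metabolic stability, read by LC-MS, using microsomes, with NADPH named in the record, with a stated time of 1 h, tested at 1 uM, in the absence of a further agent (a higher number here means that more of the compound is left, a lower number that less of the compound is left), compound 1 has the entry "not determined" (no result reported), so it offers no reference point. Going by the values given here, compound 2 (`COC(=O)c1cnc(Oc2ccc3c(c2)B(O)OC3)cn1`) gives 0%, the only number, and none of the compound is left at the end of the test. Compound 3 (`NC(=O)c1cnc(Oc2ccc3c(c2)B(O)OC3)cn1`) is the next to be read. It differs from compound 2 as follows: amino in place of methoxy on a carbonyl carbon. This is methoxycarbonyl to carbamoyl, with amino in place of methoxy on a carbonyl carbon. Among the compounds with values here, no measured step shows what this change does, so the expectation is loose. With compound 2 at 0%, a change in this assay can only go upward. The expected move is a number 65 percentage points higher from compound 2 to compound 3 (beyond the scatter), an estimated rise beyond the usual scatter. For compound 3 the estimated value is 65%, with an expected range of 30% to 95%.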

Compound 3, percent of the compound remaining: 100%
For compound 3 the middle estimate is 35 percentage points below the measured one; measured number above the stated range.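

On the carbonyl carbon whose other neighbour is an aromatic carbon, amino in place of methoxy produces a large change in this assay: a number 100 percentage points higher from compound 2 to compound 3 (beyond the scatter). This first measured step in the series shows that, with the shared core unchanged, a single exchange at this position can carry the read-out from one end of its range to the other. Nothing at hand bears on why carbamoyl and methoxycarbonyl differ so sharply here.

On these data alone, whether the rise depends on the free amino group or simply on the departure of methoxy remains open, and a methylamino or dimethylamino group on the same carbonyl carbon would help separate the two. Also open, as far as these compounds go, is whether a longer chain such as ethoxy would read like methoxy.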